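Compound 3 to compound 4: swapping one carbonyl substituent

This account rests on a few compounds, and the source may have more. Where it says the series, first, only, none or still open, it means among the compounds named here.

Measured so far in a functional assay on HCT-116 cells (Homo sapiens) for inhibition, read by ELISA, with a stated time of 24 h; a higher number here means a weaker inhibitor of growth, a lower number a stronger inhibitor of growth
- compound 1 (`O=C(Cl)/C=C/c1ccccc1OC(=O)c1ccccc1`) gives (> 100000 nM), a limit and not a number
- compound 2 (`CO/N=C/C=C/c1ccccc1OC(=O)c1ccccc1`) gives (> 100000 nM), a limit and not a number
- compound 3 (`CN1CCN(C(=O)ONC(=O)/C=C/c2ccccc2OC(=O)c2ccccc2)CC1`) gives (40400 nM)

Within the data shown here, compound 3 holds the only true number in this small set. All that stands beside it is (the limit of > 100000 nM in this assay, at which 2 of the 3 values shown sit), so it can be ranked against no other exact value.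

The next compound is compound 4 (`O=C(/C=C/c1ccccc1OC(=O)c1ccccc1)NOC(=O)c1ccccc1`). It carries phenyl in place of 4-methylpiperazin-1-yl on a carbonyl carbon.

Among the measured compounds shown here, only one step links measured compounds (a step that the two limits leave unreadable from compound 1 to compound 2). It has no readable size and involves a different group, so it offers no guide to this change. With nothing measured to point either way, no step beyond the usual scatter is expected in this assay, and no direction can be named.

The estimated step is small (a 1.0-fold lower number from compound 3 to compound 4 (0.00 log units; within the scatter)). The expected value for compound 4 is (40000 nM). The range expected for compound 4 runs from (15000 nM) to (100000 nM).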

Compound 4, concentration for 50% growth inhibition: 13600 nM
Compound 4: middle estimate off by 2.9-fold (0.47 log units), on the high side, and the stated range ends above it.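

Among these compounds, putting phenyl in place of 4-methylpiperazin-1-yl on this carbonyl carbon gives a 3.0-fold lower number from compound 3 to compound 4 (0.47 log units; beyond the scatter) in this assay, the first step in this set with a readable size. It shows that this position responds to the group it carries, and that the non-aromatic ring with its hetero atoms is not needed for growth inhibition at this level. No measured property in the data accounts for the step.

This single pair changes several things at once, so it leaves open whether the gain follows from the aromatic ring or from the loss of the nitrogen atoms. A cyclohexyl group on the same carbonyl carbon would help to separate the two, and a 4-methoxyphenyl group would test whether the phenyl ring accepts further substitution.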